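Swapping trifluoromethyl for chloro on a pyridine-bearing bicyclic amine

The compounds below may be only part of what the source reports. "The series", "measured", "known", "first", "only" and "open" are said of these compounds alone.

Three compounds share a bicyclic amine core carrying a substituted six-membered aromatic ring with one nitrogen. Compound 1 `CN1CC2C=C(c3cncc(Cl)c3)CC(C2)C1` gives 9.6 nM in an in vitro assay on SH-EP1 cells for displacement of a labelled ligand from Neuronal acetylcholine receptor; alpha4/beta2 (Homo sapiens); on this read-out lower numbers stand for stronger inhibition and higher numbers for weaker inhibition. Compound 2 `C1=C(c2cncc(Oc3ccccc3)c2)CC2CNCC1C2` gives 0.7 nM in this assay, and compound 3 `FC(F)(F)c1cncc(C2=CC3CNCC(C2)C3)c1` gives 0.7 nM. Compound 3 stands level with compound 2, and the two together show the lowest numbers of the three, while compound 1 shows a clearly higher number.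

Compound 4 `Clc1cncc(C2=CC3CNCC(C2)C3)c1` has not yet been measured. It differs from compound 3 by chloro in place of trifluoromethyl on an aromatic carbon, the position being two atoms from the ring nitrogen and meta to a group of 9 heavy atoms. For the measured compounds named here, the only measured step at this position is no change at the digits printed from compound 2 to compound 3 (within the scatter), which suggests this part of the molecule tolerates quite different groups without a shift in this assay. Compound 1 also carries chloro, but with a further change elsewhere, so its value cannot be read as a direct guide. Compound 4 is therefore expected to stay close to compound 3, with a step of a 1.4-fold higher number from compound 3 to compound 4 (0.15 log units; within the scatter), giving an estimated 1 nM with a range from 0.4 nM to 3 nM.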

Compound 4, inhibition constant: 0.4 nM
Beside the measured number, compound 4's estimate is 2.5-fold (0.40 log units) above it; measured number inside the range.
By their numbers in this assay, from the lowest: compounds 4, 2 and 3 (each within the scatter of the next); then compound 1.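

In this assay, chloro in place of trifluoromethyl gives a 1.8-fold lower number from compound 3 to compound 4 (0.24 log units; within the scatter) and chloro in place of phenoxy gives a 1.8-fold lower number from compound 2 to compound 4 (0.24 log units; within the scatter), so these three groups cannot be told apart at this position. The earlier step compared only trifluoromethyl and phenoxy, whereas chloro shows that a group of 1 heavy atom holds the same level as trifluoromethyl with 4 heavy atoms. The one step beyond the scatter lies at another place, hydrogen in place of methyl on the amine nitrogen in the ring (a 24-fold lower number from compound 1 to compound 4 (1.38 log units; beyond the scatter)), which makes that nitrogen the more sensitive of the two sites among these compounds.

Nothing available here explains these numbers. From the compounds shown here alone, it remains open whether an amine or a carboxylic acid at the aromatic position would stay at this level.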